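From a Fluorophenyl to a Naphthyl Substituent

This account rests on a few compounds, and the source may have more. Where it says the series, first, only, none or still open, it means among the compounds named here.

Of the compounds shown here, two have been measured in a functional assay on HepG2 cells (Homo sapiens) for antiproliferative activity, read by MTT assay, with a stated time of 48 h; on this read-out lower numbers stand for stronger inhibition and higher numbers for weaker inhibition. Compound 1 `COc1ccc(-c2ccc3c(c2)C(=O)C(=O)N3Cc2ccc(C#N)cc2)cc1` gives 1000 nM in this assay. Compound 2 `COc1ccc(CN2C(=O)C(=O)c3cc(-c4ccc(F)cc4)ccc32)cc1` gives 3150 nM, the higher of the two numbers. The unmeasured compound 3 `COc1ccc(CN2C(=O)C(=O)c3cc(-c4ccc5ccccc5c4)ccc32)cc1` differs from compound 2 by naphthalen-2-yl in place of 4-fluorophenyl on an aromatic carbon. Among the measured compounds shown here, no measured pair differing in one place is available, so the size of this step cannot be read from the data. A modest move toward stronger inhibition is expected, the step from compound 2 to compound 3 being estimated as a 1.8-fold lower number from compound 2 to compound 3 (0.24 log units; within the scatter). Compound 3 is therefore expected at 1800 nM, with a range from 500 nM to 6000 nM.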

Compound 3, half-maximal inhibitory concentration: > 10000 nM
Compound 3: a limit, no number; the forecaster's own chance of this, stated with the estimate: 5%; middle value at least 5.5-fold (0.74 log units) away from the limit.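

In this assay, naphthalen-2-yl in place of 4-fluorophenyl on this aromatic carbon gives an at least 3.1-fold higher number from compound 2 to compound 3 (0.50 log units; beyond the scatter). Among the compounds shown here, this is the first step that can be read at this position, and it runs toward weaker inhibition, so the second fused aromatic ring is not tolerated here without loss. Only one side of the step is bounded, by the value for compound 3, which is a limit and not a number: the limit of > 10000 nM in this assay, at which 1 of the 3 values shown sits.

The compounds shown leave open how a phenyl ring carrying an amine or a carboxylic acid would read at this position. They also leave open whether the same change would give a similar step on the core of compound 1.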